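Stereoisomers and Methyl Variants with Low Hepatocyte Clearance

The source may hold more compounds than are shown below. What is called first, only, known or untested is meant among the compounds shown, and "the series" means these compounds.

Compound 1 `C[C@@H](Nc1c(NCCCCCC(=O)NO)c(=O)c1=O)c1ccccc1` gives < 5 uL/min in an ADME assay on cells (Hepatocyte, Homo sapiens) for pharmacokinetics, read by LC-MS, with a stated time of 90 min, tested at 1 uM (on this read-out lower numbers stand for slow clearance and higher numbers for fast clearance), which is a limit of the assay and not a number.
Compound 2 `C[C@H](Nc1c(NCCCCCC(=O)NO)c(=O)c1=O)c1ccccc1` gives < 5 uL/min in this assay, again a limit.
Compound 3 `Cc1ccccc1[C@H](C)Nc1c(NCCCCCC(=O)NO)c(=O)c1=O` gives < 5 uL/min in this assay, again a limit.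

Compound 1 and compound 2 differ only in this way: the two compounds have the same atoms and bonds and differ only in configuration as drawn: 1 of 1 stereo elements differ; a stereocentre at a saturated chain carbon is drawn S in compound 2 and R in compound 1. The step that the two limits leave unreadable from compound 1 to compound 2 cannot be read, due to the limit of < 5 uL/min in this assay, at which 3 of the 3 values shown sit, and (the fact that compounds 1 and 2 differ only in the configuration as drawn). From compound 2 to compound 3 the change is methyl in place of hydrogen on an aromatic carbon, and the step that the two limits leave unreadable from compound 2 to compound 3 is likewise unreadable.

Compound 4 `Cc1cccc([C@@H](C)Nc2c(NCCCCCC(=O)NO)c(=O)c2=O)c1` has not been measured. From compound 1 it differs by methyl in place of hydrogen on an aromatic carbon; this is the same kind of change as from compound 2 to compound 3, but here the methyl sits meta to a large group rather than ortho to it. Because all three values sit at the limit of < 5 uL/min in this assay, at which 3 of the 3 values shown sit, compound 4 is expected to give 3 uL/min in this assay, with a range from 1 uL/min to 8 uL/min. The expected step is a step that the limit leaves unreadable from compound 1 to compound 4.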

Compound 4, intrinsic clearance in a liver preparation (reported as CLH), per the amount of preparation that the assay uses in the Hepatocyte assay: < 5 uL/min
Compound 4: only a limit was reported (the forecaster's own chance of this, stated with the estimate: 85%); the middle value is on the limit's open side.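

Within the data shown here, in the Hepatocyte assay compound 4 stays at a limit, as compound 1 does, so no step between them can be read. In a physicochemical assay for solubility, with a stated time of 24 h, tested at 30 mg/mL (on this read-out lower numbers stand for lower solubility and higher numbers for higher solubility), compound 1 gives 39000000 nM and compound 4 gives 82000000 nM on this read-out. That makes a 2.1-fold higher number from compound 1 to compound 4 (0.32 log units; beyond the scatter) for solubility. The compounds shown leave open how the clearance of compounds 1 to 4 compares once it is no longer hidden by the limit.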